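The source may hold more compounds than are shown below. What is called first, only, known or untested is meant among the compounds shown, and "the series" means these compounds.

Measured so far in a functional assay on CHO cells for agonist activity at Melanocortin receptor 4 (Homo sapiens), read by cAMP accumulation; a higher number here means that more compound is needed for the effect, a lower number that less compound is needed:
- compound 1, `CC(C)[C@H](NC(=O)CCN(C)C)c1cccc(F)c1N1CCN(C(=O)[C@@H]2CN(C(C)C)C[C@H]2c2ccc(C(F)(F)F)c(F)c2)CC1`: 340 nM
- compound 2, `Cc1ccc(N2CCN(C(=O)[C@@H]3CN(C4CCOCC4)C[C@H]3c3ccc(Cl)cc3)CC2)c([C@@H](NC(=O)[C@@H](C)N)C(C)C)c1`: 17 nM

Going by the values given here, two compounds carry numbers, and they share neither core nor amine-side group, so no single-point step can be drawn between them; only the two values themselves can be compared. Compound 2 gives the lower number of the two in this assay, with compound 1 sitting well above it, a gap beyond the usual scatter.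

Compound 3, `Cc1ccc(N2CCN(C(=O)[C@@H]3CN(C4CCOCC4)C[C@H]3c3ccc(Cl)cc3)CC2)c([C@@H](NC(=O)CCN)C(C)C)c1`, is the next compound to be measured. It keeps the whole core of compound 2 and changes only the acyl group on the amine:

2-aminoethyl in place of 1-aminoethyl on a carbonyl carbon

With this change the defined stereocentre of the acyl group disappears. Among the compounds with values here, no measured pair shows what this change does on this core. Compound 2 is the only anchor here, and the rearranged group is small, so the expected step from compound 2 to compound 3 in this assay is a modest rise in the number, a 2.9-fold higher number from compound 2 to compound 3 (0.47 log units; beyond the scatter), rather than a large one. Compound 3 is therefore estimated at 50 nM, with a range from 15 nM to 200 nM.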

Compound 3, half-maximal effective concentration: 6 nM
For compound 3 the middle estimate is 8.3-fold (0.92 log units) above the measured one, and the stated range ends above it.
By their numbers in this assay, from the lowest: compound 3; then compound 2; then compound 1.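

In this assay, going by these compounds alone, moving the amine along the acyl chain, 2-aminoethyl in place of 1-aminoethyl on a carbonyl carbon, gives a 2.8-fold lower number from compound 2 to compound 3 (0.45 log units; beyond the scatter) on an otherwise unchanged core, the first step that can be read at a single place. The entering and leaving groups have the same atoms and the same counts of donors and acceptors, so the step comes from how those atoms are joined, and the defined stereocentre of 1-aminoethyl is not required for a low number on this core. Nothing available accounts for the direction of this step.

Going by these compounds, whether an amine is needed at this position stays open, and a 2-hydroxyethyl group or a carboxylic acid on the same carbonyl carbon would address that. Also open, on these data alone, are the effect of a longer chain such as 3-aminopropyl and whether the same change would give a step of similar size on the core of compound 1.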